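Diaryl ether variations on a thiazolidinedione series

The source may hold more compounds than are shown below. What is called first, only, known or untested is meant among the compounds shown, and "the series" means these compounds.

Compound 1 `O=C1NC(=O)C(Cc2ccc(Oc3ccccc3)cc2)S1` gives 307 nM in a functional assay for agonist activity at Free fatty acid receptor 1 (Homo sapiens), read by FLIPR, in the presence of a further agent that is not named here; a lower number here means that less compound is needed, a higher number that more compound is needed for the effect. Compound 2 `Cc1ccc(Oc2ccc(CC3SC(=O)NC3=O)cc2)cc1C` gives 727 nM, and compound 3 `Cc1ccc(Oc2ccc(CC3SC(=O)NC3=O)cc2)cc1` gives 547 nM; compound 3 lies within the scatter of both neighbours, as seen in a 1.8-fold higher number from compound 1 to compound 3 (0.25 log units; within the scatter) and a 1.3-fold lower number from compound 2 to compound 3 (0.12 log units; within the scatter). Compound 4 `Cc1cccnc1Oc1ccc(CC2SC(=O)NC2=O)cc1` differs from compound 3 by 3-methylpyridin-2-yl in place of 4-methylphenyl on an oxygen on an aromatic ring. Within the data shown here, no measured step exchanges a ring atom for a hetero atom; the two steps that do bear on this part of the molecule, the methyl changes, are both within the scatter. The step of a 1.0-fold higher number from compound 3 to compound 4 (0.00 log units; within the scatter) is therefore expected to be small, in no particular direction. Compound 4 is estimated at 550 nM, with a range from 200 nM to 1500 nM.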

Compound 4, half-maximal effective concentration: 1090 nM
The estimate for compound 4 lay 2.0-fold (0.30 log units) below the measured number; measured number inside the range.
By their numbers in this assay, from the lowest: compounds 1, 3, 2 and 4 (each within the scatter of the next, the first and the last beyond it).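

In this assay, 3-methylpyridin-2-yl in place of 4-methylphenyl (a 2.0-fold higher number from compound 3 to compound 4 (0.30 log units; within the scatter)) remains within the scatter on its own. In place of phenyl, the same group (a 3.6-fold higher number from compound 1 to compound 4 (0.55 log units; beyond the scatter)) gives the first listed step beyond the scatter, a modest one. No measurement available here accounts for this step. It remains open whether the ring nitrogen or the methyl carries the step, as the shown compounds never vary the two separately. A carboxylic acid or an amine on this ring also remains untested among the compounds shown.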